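A few compounds are considered here, and "the series" means these few. Any claim that something is new, unique, unknown or untested is made for them only; others in the source may bear on it.

In an ADME assay on L6 cells (Rattus norvegicus) for cytotoxicity, read by fluorescence, with a stated time of 72 h (on this read-out lower numbers stand for stronger inhibition and higher numbers for weaker inhibition), compound 1 (`OCCNc1ccnc2cc(Cl)ccc12`) gives 233000 nM and stands highest of the two measured compounds. Compound 2 (`COc1cc(NC(C)CCCNC(c2ccc(CO[C@@H]3COc4nc([N+](=O)[O-])cn4C3)cc2)c2nnnn2C(C)(C)C)c2ncccc2c1`) gives 75900 nM in this assay and so sits lower, by a gap beyond the usual scatter. The two differ too widely to offer a direct comparison. Compound 3 (`NCCNc1ccnc2cc(Cl)ccc12`) has not yet been measured. It departs from compound 1 in one place: amino in place of hydroxy on a saturated chain carbon, two bonds along the chain from a nitrogen on an aromatic ring with amino in place of hydroxy on a saturated chain carbon, two bonds along the chain from a nitrogen on an aromatic ring. Among the measured compounds shown here, no measured pair shows this change, so only a modest move towards a lower number in this assay is expected, and it may stay within the scatter. The expected shift is a 2.1-fold lower number from compound 1 to compound 3 (0.33 log units; beyond the scatter) as a rough estimate. For compound 3 the estimate is 110000 nM with a range from 35000 nM to 280000 nM expected for the measurement.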

Compound 3, half-maximal inhibitory concentration: 21200 nM
Beside the measured number, compound 3's estimate is 5.2-fold (0.72 log units) above it, outside the stated range (below it).
By their numbers in this assay, from the lowest: compound 3; then compound 2; then compound 1.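

Amino in place of hydroxy on a saturated chain carbon, two bonds along the chain from a nitrogen on an aromatic ring, gives an 11-fold lower number from compound 1 to compound 3 (1.04 log units; beyond the scatter) in this assay and so reaches well beyond the scatter. This position therefore matters on this read-out, even though the leaving and entering groups match in heavy-atom count, hydrogen-bond donors, hydrogen-bond acceptors and net charge as computed from the two structures. Nothing shown accounts for the size of this step.

Going by these compounds, whether a dimethylamino group, a carboxylic acid or a longer chain carrying the amine would move the number further at this place remains open. This single pair also leaves open whether the same change would give a similar step on another core, such as that of compound 2.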